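The compounds below may be only part of what the source reports. "The series", "measured", "known", "first", "only" and "open" are said of these compounds alone.

Measured compounds in an assay for inhibition of Tryptophan 2,3-dioxygenase (Homo sapiens), with stated times of 10 min and 60 min, tested at 100 uM; a lower number here means a weaker effect, a higher number a stronger effect of the compound at the concentration tested:
compound 1 `Oc1ccc(CNc2cc(C(F)(F)F)cc3[nH]ncc23)cc1` — 91%
compound 2 `FC(F)(F)c1cc(NC[C@@H]2CCCCN2)c2cn[nH]c2c1` — 88%
compound 3 `FC(F)(F)c1cc(NC[C@H]2CCCCN2)c2cn[nH]c2c1` — 90%

Compound 1 holds the highest of the three numbers, though its steps to the others, a number 1 percentage points lower from compound 1 to compound 3 (within the scatter) and a number 3 percentage points lower from compound 1 to compound 2 (within the scatter), are both within the scatter. The remaining pair shows a number 2 percentage points higher from compound 2 to compound 3 (within the scatter), as expected because of the fact that compounds 2 and 3 differ only in the configuration as drawn.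

Compound 4 `O=[N+]([O-])c1ccc(CNc2cc(C(F)(F)F)cc3[nH]ncc23)cc1` differs from compound 1 in one place: nitro in place of hydroxy on an aromatic carbon. For the measured compounds named here, no measured step touches this aromatic carbon; the measured steps replace the whole 4-hydroxyphenyl with piperidin-2-yl and stay within the scatter. Given that every measured change leaves this assay near the top of the range, compound 4 is expected to do the same, with a step of a number 5 percentage points lower from compound 1 to compound 4 (within the scatter) not beyond the scatter. The estimate for compound 4 is 86%, in the range 70% to 97%.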

Compound 4, a percentage reported as inhibition, at one concentration (the size of the read-out at that concentration, not a potency): 64%
Compound 4: the middle estimate sits 22 percentage points above what was measured; the whole stated range lies above it.
By their numbers in this assay, from the lowest: compound 4; then compounds 2, 3 and 1 (each within the scatter of the next).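

In this assay, nitro in place of hydroxy on this aromatic carbon, para to a large group, gives a number 27 percentage points lower from compound 1 to compound 4 (beyond the scatter), the only step shown that lies beyond the scatter. This aromatic carbon is therefore not indifferent to its substituent, which the replacements of the whole 4-hydroxyphenyl in compounds 2 and 3 could not show. Nothing available accounts for the size of this step. Still open, as far as these compounds go, is whether the drop follows from removing hydroxy or from introducing nitro. An amine, a methoxy group or a carboxylic acid on this carbon would help separate the two.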